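Amide side-chain swap in a low-efficacy alkyne series

The source may report more compounds than this note shows. Statements on the series, on what has been measured and on what is new or still open speak of the compounds shown alone.

Two measured compounds share the same core and differ only in the group on the amide-type nitrogen. Compound 1 `Cc1nc(C#Cc2cccc(F)c2)ccc1C(=O)N[C@H](C)C(C)(C)O` gives in an ADME assay on HEK293 cells for agonist activity at metabotropic glutamate receptor 5 (Rattus norvegicus), read by fluorescence and calcium flux (a higher number here means a larger maximal response, a lower number a smaller maximal response), a value of 9.2%. Compound 2 `CC(C)[C@H](C)NC(=O)c1ccc(C#Cc2cccc(F)c2)cn1` gives in this assay a value of 13.1%. Compound 2 holds the higher of the two numbers shown, but the gap to compound 1 lies within the scatter, so the two are read as equivalent: both sit at a small fraction of the reference response.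

Compound 3 `CC(C)(O)CNC(=O)c1ccc(C#Cc2cccc(F)c2)cn1` is not yet measured in this assay. It is derived from compound 2 by the change (2-hydroxy-2-methylpropyl in place of 1,2-dimethylpropyl on an amide-type nitrogen). Compound 1 already carries a hydroxy-bearing chain on the same nitrogen and sits at the same low level as compound 2, so the series gives no sign that this kind of change moves the maximal response. The step is therefore expected to be none beyond the scatter, and compound 3 is expected to give about 10% in this assay, with a range of 3% to 20%, which corresponds to an estimated a number 3.1 percentage points lower from compound 2 to compound 3 (within the scatter).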

Compound 3, largest response reached (reported as efficacy), in percent of the reference or control that the assay uses: 20%
The estimate for compound 3 lay 10 percentage points below the measured number; low and high end bracket the measured number.
By their numbers in this assay, from the lowest: compounds 1, 2 and 3 (each within the scatter of the next, the first and the last beyond it).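

Among the compounds shown here, the step on this amide-type nitrogen gives the first direct comparison of a hydroxy-bearing chain with an all-carbon chain on an otherwise unchanged structure: in this assay 2-hydroxy-2-methylpropyl in place of 1,2-dimethylpropyl gives a number 6.9 percentage points higher from compound 2 to compound 3 (within the scatter). The change enters a hydrogen-bond donor and acceptor and removes the defined stereocentre, yet compound 2 and compound 3 read as equivalent, so this position accepts the hydroxy-bearing chain with no maximal response distinguishable from that of the all-carbon chain, and compound 3 stands at 20% in this assay, still a small fraction of the reference response. No measurement shown here bears on the origin of this result, so the step stands as an observation only.

Still open, going by these compounds, is whether a longer chain, an amine or a carboxylic acid on the same nitrogen would move the maximal response beyond the scatter from the level of compound 2. Also open, on these data alone, is whether a chain carrying a ring on this nitrogen would stay at the same low level in this assay.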